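A Fluoro-for-Hydrogen Step Repeated on a Brominated Core

The source may report more compounds than this note shows. Statements on the series, on what has been measured and on what is new or still open speak of the compounds shown alone.

Three compounds have been measured in a functional assay on HepG2 cells (Homo sapiens) for antiproliferative activity, read by MTT assay, with a stated time of 48 h; a lower number here means a stronger inhibitor, a higher number a weaker inhibitor:

Compound 1, `O=[N+]([O-])c1cc(C(F)(F)F)cc([N+](=O)[O-])c1Oc1ccccc1/C=N\OCc1ccccc1`, gives 1330 nM.
Compound 2, `O=[N+]([O-])c1cc(C(F)(F)F)cc([N+](=O)[O-])c1Oc1ccccc1/C=N\OCc1ccccc1F`, gives 680 nM.
Compound 3, `O=[N+]([O-])c1cc(C(F)(F)F)cc([N+](=O)[O-])c1Oc1ccc(Br)cc1/C=N\OCc1ccccc1`, gives 1180 nM.

Compound 2 differs from compound 1 by a single change, (fluoro in place of hydrogen on an aromatic carbon). That change brought a 2.0-fold lower number from compound 1 to compound 2 (0.29 log units; within the scatter), so the two numbers cannot be told apart with confidence.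

Compound 3 carries a different single change relative to compound 1, (bromo in place of hydrogen on an aromatic carbon). Its effect was a 1.1-fold lower number from compound 1 to compound 3 (0.05 log units; within the scatter), again a difference too small to read anything into.

Compound 4, `O=[N+]([O-])c1cc(C(F)(F)F)cc([N+](=O)[O-])c1Oc1ccc(Br)cc1/C=N\OCc1ccccc1F`, has not yet been measured in this assay. It differs from compound 3 by fluoro in place of hydrogen on an aromatic carbon. Among the compounds with values here, this is the same change as the one from compound 1 to compound 2: the group that leaves, the group that enters and the surroundings of the place are described in the same words in both cases. The only difference between the two cores is the bromo group described above, whose own effect was within the scatter.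

The expected step from compound 3 to compound 4 in this assay is therefore a 1.8-fold lower number from compound 3 to compound 4 (0.26 log units; within the scatter), resting on the earlier step of a 2.0-fold lower number from compound 1 to compound 2 (0.29 log units; within the scatter) and on the small effect of the bromo group a 1.1-fold lower number from compound 1 to compound 3 (0.05 log units; within the scatter). Compound 4 is accordingly estimated to give about 650 nM in this assay, most likely between 300 nM and 1400 nM.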

Compound 4, half-maximal inhibitory concentration: 890 nM
For compound 4 the middle estimate is 1.4-fold (0.14 log units) below the measured one; the measured number falls inside the stated range.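

In this assay, the change from benzyl to 2-fluorobenzyl on the brominated core gave a 1.3-fold lower number from compound 3 to compound 4 (0.12 log units; within the scatter), and this step agrees with the one seen for the same change on the core of compound 1: the same change on two cores in this assay, a 2.0-fold lower number (0.29 log units; within the scatter) from compound 1 to compound 2 and a 1.3-fold lower number (0.12 log units; within the scatter) from compound 3 to compound 4, 1.5-fold (0.17 log units) apart, within the scatter of two such steps. Seen from the other side, adding bromo to the core that already carries the 2-fluorobenzyl group gave a 1.3-fold higher number from compound 2 to compound 4 (0.12 log units; within the scatter), which also agrees with its earlier counterpart: the same change on two cores in this assay, a 1.1-fold lower number (0.05 log units; within the scatter) from compound 1 to compound 3 and a 1.3-fold higher number (0.12 log units; within the scatter) from compound 2 to compound 4, 1.5-fold (0.17 log units) apart, within the scatter of two such steps. The two changes therefore show no sign of interfering with each other across these four compounds, but every step among them lies within the scatter, so the data do not show that either change has a real effect on the number, only that no clear difference appears between the two cores.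

The compounds shown leave open whether a methoxy group, an amine or a carboxylic acid on the benzyl ring, or a longer chain in place of benzyl, would move the number by more than the scatter. They also leave open whether fluoro and bromo would behave the same way on a core without the trifluoromethyl group.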